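Trading One Methyl for Fluorine in a Lung Cancer Cell Assay

The compounds below may be only part of what the source reports. "The series", "measured", "known", "first", "only" and "open" are said of these compounds alone.

Compound 1 `COc1cc(NC(=O)Nc2cc(Nc3ccc(C)c(C)c3)ncn2)cc(OC)c1` was tested in a functional assay on NCI-H520 cells (Homo sapiens) for inhibition, read by MTT assay, with a stated time of 48 h, tested at 10 uM (a lower number here means less inhibition, a higher number more inhibition at the concentration tested (going by the name of the read-out)), where compound 1 gives 29.5%. Compound 2 `COc1cc(Nc2cc(NC(=O)Nc3c(Cl)cccc3Cl)ncn2)cc(C(F)(F)F)c1` gives 23.1% in this assay; the two numbers lie within the usual scatter of each other, so neither compound is set apart from the other. Compound 3 `COc1cc(NC(=O)Nc2cc(Nc3cc(C)cc(F)c3)ncn2)cc(OC)c1` differs from compound 1 by 3-fluoro-5-methylphenyl in place of 3,4-dimethylphenyl on a nitrogen on an aromatic ring. For the measured compounds named here, no measured pair shows this change, so no step in this assay beyond the scatter is expected, in either direction. Compound 3 is therefore expected to give 27%, within 12% to 42%. The expected step is a number 2.5 percentage points lower from compound 1 to compound 3 (within the scatter).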

Compound 3, a percentage reported as inhibition, at one concentration (the size of the read-out at that concentration, not a potency): 24.5%
The estimate for compound 3 lay 2.5 percentage points above the measured number; the measured number falls inside the stated range.
By their numbers in this assay, from the lowest: compounds 2, 3 and 1 (each within the scatter of the next).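

For the compounds shown here, putting 3-fluoro-5-methylphenyl in place of 3,4-dimethylphenyl gives the first comparison in which only this group on the nitrogen changes. In this assay, the result is a number 5 percentage points lower from compound 1 to compound 3 (within the scatter), so the two groups are not told apart here. The readings therefore show that this exchange, which also alters the ring's substitution pattern, leaves no step beyond the scatter. On these data alone, whether an amine or a carboxylic acid on this ring would do so remains open. Nothing measured here explains the result.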